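Removing the Fluorine From the Fused Ring of Compound 2

The source may hold more compounds than are shown below. What is called first, only, known or untested is meant among the compounds shown, and "the series" means these compounds.

Compound 2 `Cc1cc(-c2nc3ccc(F)cc3s2)ccc1N` was tested in a functional assay on NCI-H226 cells (Homo sapiens) for inhibition (a lower number here means a stronger inhibitor of growth, a higher number a weaker inhibitor of growth), where compound 2 gives 60300 nM. Among the two compounds measured so far this is the highest number; its nearest neighbour is compound 1 `Nc1ccc(-c2nc3ccc(F)cc3s2)cc1Cl`, which in this assay gives 14100 nM. Within the data shown here, the only measured step, a 4.3-fold higher number from compound 1 to compound 2 (0.63 log units; beyond the scatter), involves methyl in place of chloro on an aromatic carbon.

Compound 3 `Cc1cc(-c2nc3ccccc3s2)ccc1N` has not yet been measured. It differs from compound 2 in one place: hydrogen in place of fluoro on an aromatic carbon. Among the measured compounds shown here, this change sits on the fused two-ring part of the shared core, a place left untouched by the single measured step, so no measured step bears directly on it. With nothing to point either way, the step expected in this assay is a 1.0-fold lower number from compound 2 to compound 3 (0.00 log units; within the scatter), within the scatter. Compound 3 is therefore estimated at 60000 nM, with a range from 20000 nM to 180000 nM.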

Compound 3, concentration for 50% growth inhibition: 18600 nM
Estimate against measurement, compound 3: 3.2-fold (0.51 log units) above; the measured number lies below the stated range.
By their numbers in this assay, from the lowest: compounds 1 and 3 (each within the scatter of the next); then compound 2.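

Changes on the fused part of the shared core, which the earlier step did not touch, can shift the number in this assay. With the methyl compound as the background, hydrogen in place of fluoro on this aromatic carbon gives a 3.2-fold lower number from compound 2 to compound 3 (0.51 log units; beyond the scatter), a modest step beyond the scatter, so here the fluoro compound is the weaker inhibitor of growth. Nothing available explains why the number falls when the fluorine leaves.

Among these compounds, whether the same step holds when chloro takes the place of methyl remains open, since compound 1 has no counterpart with hydrogen in place of fluoro. From the compounds shown here alone, it is also open how the number would move with a different group at this position, such as methoxy or an amine.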